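Swapping the aglycone on a shared galloyl glucoside core

The compounds below may be only part of what the source reports. "The series", "measured", "known", "first", "only" and "open" are said of these compounds alone.

Measured so far:
compound 1, `CC1=CC[C@@H](C(C)(C)O[C@@H]2O[C@H](COC(=O)c3cc(O)c(O)c(O)c3)[C@@H](O)[C@H](O)[C@H]2O)CC1`, 48.4%
compound 2, `C=CCc1cc(OC)c(O)c(O[C@@H]2O[C@H](COC(=O)c3cc(O)c(O)c(O)c3)[C@@H](O)[C@H](O)[C@H]2O)c1`, 53.6%

Of the compounds shown here, two have been tested so far, both built on the shared core. In a functional assay, read by spectrophotometry, with a stated time of 30 min, tested at 10 uM (a higher number here means a stronger effect of the compound at the concentration tested, a lower number a weaker effect), compound 1 gives 48.4%, the lower of the two numbers. Compound 2 gives 53.6% in this assay, a figure that sits within the usual scatter of compound 1, so the two cannot be told apart on this read-out.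

Compound 3, `C=CCc1ccc(O[C@@H]2O[C@H](COC(=O)c3cc(O)c(O)c(O)c3)[C@@H](O)[C@H](O)[C@H]2O)c(OC)c1`, has not yet been measured in this assay. Its difference from compound 1 is 4-allyl-2-methoxyphenyl in place of 1-methyl-1-(4-methylcyclohex-3-en-1-yl)ethyl on an oxygen on a saturated carbon

For the measured compounds named here, with only two numbers, both close together, there is no basis for expecting a large move in either direction. The expected step is a number 1.6 percentage points higher from compound 1 to compound 3 (within the scatter), that is, nothing clearly beyond the scatter. Compound 3 is therefore estimated at 50% in this assay, with a likely range from 32% to 68%.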

Compound 3, a percentage reported as activity, at one concentration (the size of the read-out at that concentration, not a potency): 60.9%
The estimate for compound 3 lay 10.9 percentage points below the measured number; low and high end bracket the measured number.
By their numbers in this assay, from the lowest: compounds 1, 2 and 3 (each within the scatter of the next, the first and the last beyond it).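

In this assay, for the compounds shown here, 4-allyl-2-methoxyphenyl in place of 1-methyl-1-(4-methylcyclohex-3-en-1-yl)ethyl gives a number 12.5 percentage points higher from compound 1 to compound 3 (beyond the scatter) and is the first step to clear the scatter. It shows that the group on this oxygen can shift the read-out measurably while the shared core stays the same, although the step is modest. Nothing available accounts for this rise.

The change swaps a non-aromatic carbon ring for an aromatic one and also brings in the allyl and methoxy groups, so the effect of each part cannot be separated. As far as these compounds go, whether a plain phenyl would keep the higher number, or whether an amine or a carboxylic acid on the aromatic ring would raise or lower it, remains open.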